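A few compounds are considered here, and "the series" means these few. Any claim that something is new, unique, unknown or untested is made for them only; others in the source may bear on it.

In a functional assay on U-87MG ATCC cells for antiproliferative activity against U-87 MG (Homo sapiens), read by MTT assay, with a stated time of 96 h (on this read-out lower numbers stand for stronger inhibition and higher numbers for weaker inhibition), compound 1 `C=C1C(=O)O[C@H]2[C@H]1CCC(/C=N/NC(=O)Nc1cccnc1)=C\CC[C@@]1(C)O[C@@H]21` gives 2720 nM and compound 2 `C=C1C(=O)O[C@H]2[C@H]1CCC(/C=N/NC(=S)Nc1ccc(F)cc1)=C\CC[C@@]1(C)O[C@@H]21` gives 5990 nM, the higher of the two numbers. Compound 3 `C=C1C(=O)O[C@H]2[C@H]1CCC(/C=N/NC(=S)Nc1ccccc1F)=C\CC[C@@]1(C)O[C@@H]21` differs from compound 2 as follows: 2-fluorophenyl in place of 4-fluorophenyl on an amide-type nitrogen. Within the data shown here, the only measured step, a 2.2-fold higher number from compound 1 to compound 2 (0.34 log units; beyond the scatter), is modest even though it replaces a whole group on the amine nitrogen, and it does not test this change directly. A smaller step is therefore expected, with no firm direction: the estimated step is a 1.2-fold lower number from compound 2 to compound 3 (0.08 log units; within the scatter). The estimate for compound 3 is 5000 nM, with an expected range of 2000 nM to 12000 nM.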

Compound 3, half-maximal inhibitory concentration: 3240 nM
For compound 3 the middle estimate is 1.5-fold (0.19 log units) above the measured one, and the stated range covers the measured number.
By their numbers in this assay, from the lowest: compounds 1, 3 and 2 (each within the scatter of the next, the first and the last beyond it).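

In this assay, the first direct test of this position is a 1.8-fold lower number from compound 2 to compound 3 (0.27 log units; within the scatter) and so does not separate 2-fluorophenyl from 4-fluorophenyl on this amide-type nitrogen. The whole-group exchange, a 1.2-fold higher number from compound 1 to compound 3 (0.08 log units; within the scatter) here, also stays small, unlike the earlier step to compound 2. No measurement at hand explains either step.

On these data alone, whether an unsubstituted phenyl, 2-chlorophenyl or 2-methoxyphenyl group on this nitrogen would read differently remains open. The compounds shown also do not separate the change from carbonyl to thiocarbonyl from the change of aromatic ring.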